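Swapping nitro for trifluoromethoxy on compound 1

A few compounds are considered here, and "the series" means these few. Any claim that something is new, unique, unknown or untested is made for them only; others in the source may bear on it.

- compound 1 `CN1c2ccc(NC(=O)Nc3ccc([N+](=O)[O-])cc3)cc2C(C)(C)C(=O)C1(C)C` gives 3800 nM
- compound 2 `CN1c2ccc(NC(=S)Nc3ccc(C(F)(F)F)cc3)cc2C(C)(C)C(=O)C1(C)C` gives 3900 nM

In a functional assay on A2780 cells (Homo sapiens) for inhibition, with a stated time of 72 h (on this read-out higher numbers stand for weaker inhibition and lower numbers for stronger inhibition), compound 1 gives 3800 nM, level within the usual scatter with compound 2 at 3900 nM. Compound 3 `CN1c2ccc(NC(=O)Nc3ccc(OC(F)(F)F)cc3)cc2C(C)(C)C(=O)C1(C)C` keeps the core of compound 1 but carries trifluoromethoxy in place of nitro on an aromatic carbon. Among the compounds with values here, no measured pair shows this change alone. Within the data shown here, the only guide is compound 2, which gives 3900 nM and has a different structure from compound 1 without leaving the scatter. The expected change is therefore none beyond the scatter, and the estimated move is a 1.3-fold lower number from compound 1 to compound 3 (0.10 log units; within the scatter). For compound 3 the estimated value is 3000 nM, with an expected range from 1000 nM to 8000 nM.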

Compound 3, half-maximal inhibitory concentration: 2400 nM
Estimate against measurement, compound 3: 1.3-fold (0.10 log units) above; measured number inside the range.
By their numbers in this assay, from the lowest: compounds 3, 1 and 2 (each within the scatter of the next).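

Within the data shown here, this is the first single change read at this place, on an aromatic carbon para to a large group: trifluoromethoxy in place of nitro gives a 1.6-fold lower number from compound 1 to compound 3 (0.20 log units; within the scatter) in this assay on the shared core. On this core, then, these two groups cannot be told apart, although they differ in heavy atoms and hydrogen-bond acceptors. No measurement here speaks to why they read alike. Still open, on these data alone, is whether a group of another kind at this place, such as an amine or a carboxylic acid, would move the number beyond the scatter.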